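The source may hold more compounds than are shown below. What is called first, only, known or untested is meant among the compounds shown, and "the series" means these compounds.

Measured so far in a physicochemical assay for lipophilicity, using the shake flask method, at pH 7.4 (on this read-out higher numbers stand for higher lipophilicity and lower numbers for lower lipophilicity), are two compounds:
- compound 1 `CCCCCCN1CCc2ccccc2C1` gives 3.3 as its value
- compound 2 `COc1ccccc1OCCOC1CCOCC1` gives "nd" (no result reported) as its entry

Going by the values given here, compound 2 therefore stands without a single number in this assay and compound 1 is the only compound with a value. Among the compounds with values here, no two measured compounds differ in one place, so no measured step is available to size a change.

Within the data shown here, compound 3 `COc1ccccc1OCCON1CCOCC1` is the next compound to be read, and its closest relative is the one without a number. The structural change is morpholin-4-yl in place of oxan-4-yl on an oxygen on a saturated carbon with morpholin-4-yl in place of oxan-4-yl on an oxygen on a saturated carbon. A modest step toward lower numbers is expected for this change, although it may not go beyond the usual scatter, and it cannot be checked against a value here. The estimate has no measured starting point in the closest relative, so its range is kept wide. Compound 3 is expected at 1.6 in this assay, with an estimated range from 0.9 to 2.3 as the likely span.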

Compound 3, distribution coefficient: 1.3
Estimate against measurement, compound 3: 0.30 log units above, and the stated range covers the measured number.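

No step can be read between compound 2 and compound 3 in this assay; compound 2 has no single number there, and compound 3 gives 1.3. No supporting evidence bears on this result. The compounds shown leave open how far morpholin-4-yl in place of oxan-4-yl moves the value in this assay.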